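Swapping Phenyl for Pyridin-2-yl: Expected Cytotoxicity

The compounds below may be only part of what the source reports. "The series", "measured", "known", "first", "only" and "open" are said of these compounds alone.

Compound 1 `Cc1cc(C#N)ccc1-c1ccnc(NCc2cc(-c3ccccc3)[nH]n2)c1`: in an ADME assay on CEM174 cells (Homo sapiens) for cytotoxicity (on this read-out lower numbers stand for higher toxicity in this test and higher numbers for lower toxicity in this test), compound 1 gives > 10000 nM, which is a limit of the assay.
Compound 2 `Cc1cc(C#N)ccc1-c1ccnc(NCc2n[nH]c(-c3ccccc3)c2Cl)c1`: in this assay compound 2 gives > 10000 nM, again a limit.

Compound 1 therefore stands only at a limit, not at a number; the same holds for every value shown, since (the limit of > 10000 nM in this assay, at which 2 of the 2 values shown sit). Within the data shown here, the single measured step, a step that the two limits leave unreadable from compound 1 to compound 2, a chloro in place of hydrogen on an aromatic carbon, cannot be read for that reason.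

Compound 3 `Cc1cc(C#N)ccc1-c1ccnc(NCc2cc(-c3ccccn3)[nH]n2)c1` differs from compound 1 by pyridin-2-yl in place of phenyl on an aromatic carbon. Among the measured compounds shown here, no measured step bears on this change, and the one step that exists is unreadable. With the shared core staying at the limit in both cases shown, the expected step that the limit leaves unreadable from compound 1 to compound 3 is none beyond the scatter. Compound 3 is thus expected to give 15000 nM in this assay, within 6000 nM to 40000 nM, most likely reported as a limit again.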

Compound 3, half-maximal cytotoxic concentration: > 10000 nM
Compound 3: a limit, no number; the forecaster's own chance of this, stated with the estimate: 85%; the middle value is on the limit's open side.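

Among these compounds, compound 3 also gives only a limit, so no step from compound 1 to compound 3 can be read: the limit of > 10000 nM in this assay, at which 3 of the 3 values shown sit. The compounds shown leave open what actual number compound 1, compound 2 and compound 3 would each reach in this assay, and whether pyridin-2-yl or chloro shifts it.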